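The compounds below may be only part of what the source reports. "The series", "measured", "known", "first", "only" and "open" are said of these compounds alone.

Measured so far in a functional assay on L1210 cells (Mus musculus) for inhibition, read by cell counting, with a stated time of 2 days; on this read-out higher numbers stand for weaker inhibition and lower numbers for stronger inhibition:
compound 1 `C=C(Br)C(=O)Nc1cccc(-c2cn3nc(-c4ccc(OC)c(OC)c4)sc3n2)c1` gives 42 nM.
compound 2 `C=C(Br)C(=O)Nc1cccc(-c2cn3c(-c4ccccc4)csc3n2)c1` gives 1300 nM.
compound 3 `Nc1cccc(-c2cn3nc(Cc4ccc(Cl)cc4)sc3n2)c1` gives 16000 nM.

Compound 1 holds the lowest number of the three; its gaps to compound 2 and to compound 3 both lie beyond the scatter, so it is the most potent of the set. Compound 4 `C=C(Br)C(=O)Nc1cccc(-c2cn3nc(-c4ccc(Cl)cc4)sc3n2)c1` keeps the core of compound 1 and its amide; the change is 4-chlorophenyl in place of 3,4-dimethoxyphenyl on an aromatic carbon. Among the compounds with values here, no measured pair isolates this change, and compound 3 differs from compound 1 in its core and in lacking the amide, so its number says little here. In this assay a small to moderate step towards weaker inhibition is expected, within or just beyond the scatter. Compound 4 is thus expected to give 150 nM (range 30 nM to 800 nM). The expected step is a 3.6-fold higher number from compound 1 to compound 4 (0.55 log units; beyond the scatter).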

Compound 4, half-maximal inhibitory concentration: 1400 nM
Beside the measured number, compound 4's estimate is 9.3-fold (0.97 log units) below it; measured number outside the range, above it.
By their numbers in this assay, from the lowest: compound 1; then compounds 2 and 4 (each within the scatter of the next); then compound 3.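

In this assay the aryl group at this place on the shared core matters strongly: with the core and the bromoacrylamide held constant, 4-chlorophenyl in place of 3,4-dimethoxyphenyl gives a 33-fold higher number from compound 1 to compound 4 (1.52 log units; beyond the scatter) as a large step. The earlier compounds shown here could not isolate this position, since each differs from compound 1 in more than one place. Nothing available accounts for the size of this loss. Still open, going by these compounds, is whether the two methoxy groups or the chlorine drive the step. A 4-methoxyphenyl or 3,4-dichlorophenyl group at this place would separate the two.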